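The compounds below may be only part of what the source reports. "The series", "measured", "known", "first", "only" and "open" are said of these compounds alone.

Three compounds share one core and differ only in the group on a saturated chain carbon bound to a double-bonded chain carbon. Compound 1 `C/C=C/C(=O)Nc1cc2c(N3CCc4ccccc43)ncnc2cc1OC` gives 8120 nM in a functional assay on PC-3 cells (Homo sapiens) for antiproliferative activity, read by MTT assay, with a stated time of 72 h; a higher number here means a weaker inhibitor, a lower number a stronger inhibitor. Compound 2 `CC/C=C/C(=O)Nc1cc2c(N3CCc4ccccc43)ncnc2cc1OC` gives 5890 nM in this assay, and compound 3 `COc1cc2ncnc(N3CCc4ccccc43)c2cc1NC(=O)/C=C/CN(C)C` gives 2190 nM in this assay. Compound 3 stands lowest of the three, by a 2.7-fold lower number from compound 2 to compound 3 (0.43 log units; beyond the scatter) and by a 3.7-fold lower number from compound 1 to compound 3 (0.57 log units; beyond the scatter), both beyond the scatter, whereas the change a 1.4-fold lower number from compound 1 to compound 2 (0.14 log units; within the scatter) stays within it. Compound 4 `COc1cc2ncnc(N3CCc4ccccc43)c2cc1NC(=O)/C=C/CN1CCCC1` carries pyrrolidin-1-yl in place of dimethylamino on a saturated chain carbon bound to a double-bonded chain carbon. Going by the values given here, no measured step exchanges one amine for another at this position; the steps that bear on it are those that introduced the dimethylamino group, a 3.7-fold lower number from compound 1 to compound 3 (0.57 log units; beyond the scatter) and a 2.7-fold lower number from compound 2 to compound 3 (0.43 log units; beyond the scatter), both modest. With an amine kept at the same place and only its shape altered, one expects a step smaller than these and most likely none beyond the scatter, a 1.1-fold lower number from compound 3 to compound 4 (0.04 log units; within the scatter). The estimate for compound 4 in this assay is therefore 2000 nM, with a range from 800 nM to 5000 nM.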

Compound 4, half-maximal inhibitory concentration: 2620 nM
Compound 4: the middle estimate sits 1.3-fold (0.12 log units) below what was measured; low and high end bracket the measured number.
By their numbers in this assay, from the lowest: compounds 3 and 4 (each within the scatter of the next); then compounds 2 and 1 (each within the scatter of the next).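

Pyrrolidin-1-yl and dimethylamino cannot be told apart at this position in this assay, with a 1.2-fold higher number from compound 3 to compound 4 (0.08 log units; within the scatter), so closing the amine into a five-membered ring and adding heavy atoms there gives no readable difference. The ring-bearing amine also stands apart from the groups without nitrogen, with a 2.2-fold lower number from compound 2 to compound 4 (0.35 log units; beyond the scatter) and a 3.1-fold lower number from compound 1 to compound 4 (0.49 log units; beyond the scatter), so the modest advantage seen with compound 3 is not confined to dimethylamino among the compounds shown. No evidence is available that explains these results.

The compounds shown leave open whether six-membered amines such as piperidine or morpholine would fit the same pattern. They also leave open whether cyclopentyl, an all-carbon ring, would match pyrrolidin-1-yl here, which would test whether the ring nitrogen matters.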